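Swapping the arylidene group on a shared amide core

This account rests on a few compounds, and the source may have more. Where it says the series, first, only, none or still open, it means among the compounds named here.

The two measured compounds share one core and differ only in the aryl group on a double-bonded chain carbon bound to a double-bonded ring carbon. Compound 1 `COc1ccc(/C=C2/SC(N3CCC[C@H]3C(=O)Nc3ccc4ncnc(Nc5cccc(Cl)c5)c4c3)=NC2=O)cc1` carries a 4-methoxyphenyl there, and in a functional assay on A549 cells (Homo sapiens) for antiproliferative activity, read by MTT assay (a higher number here means a weaker inhibitor, a lower number a stronger inhibitor), compound 1 gives 31700 nM. Compound 2 `Cc1cccc(/C=C2/SC(N3CCC[C@H]3C(=O)Nc3ccc4ncnc(Nc5cccc(Cl)c5)c4c3)=NC2=O)n1` carries a 6-methylpyridin-2-yl instead, and in this assay compound 2 gives 8500 nM. Among the measured compounds shown here, that single exchange produced a 3.7-fold lower number from compound 1 to compound 2 (0.57 log units; beyond the scatter), so compound 2 holds the lowest number of the two, with compound 1 as its only neighbour.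

Compound 3 `O=C1N=C(N2CCC[C@H]2C(=O)Nc2ccc3ncnc(Nc4cccc(Cl)c4)c3c2)S/C1=C/c1ccc(-c2ccccc2)cc1` changes the same position again: 4-phenylphenyl in place of 6-methylpyridin-2-yl on a double-bonded chain carbon bound to a double-bonded ring carbon. For the measured compounds named here, only the step from compound 1 to compound 2 bears on this, and it shows that replacing the aryl group at this place moves the number by a modest amount, in this instance toward lower values with a pyridinyl. Removing that pyridinyl again for a carbon-only 4-phenylphenyl is therefore expected to give a modest rise, and compound 3 is estimated at 15000 nM, within 4000 nM to 60000 nM, a step of a 1.8-fold higher number from compound 2 to compound 3 (0.25 log units; within the scatter).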

Compound 3, half-maximal inhibitory concentration: 24200 nM
Compound 3: the middle estimate sits 1.6-fold (0.21 log units) below what was measured, and the stated range covers the measured number.
By their numbers in this assay, from the lowest: compound 2; then compounds 3 and 1 (each within the scatter of the next).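

Going from the 6-methylpyridin-2-yl to the 4-phenylphenyl gives a 2.8-fold higher number from compound 2 to compound 3 (0.45 log units; beyond the scatter) and so takes back most of what the first exchange gained, leaving compound 2 as the strongest inhibitor of the three. The phenyl in place of methoxy on an aromatic carbon gives only a 1.3-fold lower number from compound 1 to compound 3 (0.12 log units; within the scatter) and so leaves compound 1 and compound 3 indistinguishable in this assay, while compound 2 stands apart from both. Nothing at hand explains why these numbers differ. The compounds shown cannot separate the ring nitrogen of the 6-methylpyridin-2-yl from its methyl as the source of the lower number. As far as these compounds go, how an amine or a carboxylic acid on the aryl group at this place would read in this assay also remains open.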